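The compounds below may be only part of what the source reports. "The series", "measured", "known", "first", "only" and "open" are said of these compounds alone.

Measured compounds in a functional assay on SW-620 cells (Homo sapiens) for inhibition, read by MTT assay, with a stated time of 72 h; on this read-out lower numbers stand for stronger inhibition and higher numbers for weaker inhibition:
- compound 1, `O=C1O[C@H]([C@@H](O)Cn2ccc(NC(=O)c3ccccc3)nc2=O)C(OCc2ccccc2)=C1OCc1ccccc1`: > 100000 nM (a limit of the assay, not a number)
- compound 2, `NC1(CCn2ccc(=O)[nH]c2=O)OC(=O)C(OCc2ccccc2)=C1OCc1ccccc1`: > 100000 nM (a limit of the assay)
- compound 3, `O=C1O[C@H]([C@@H](O)Cn2c(=O)[nH]c(=O)[nH]c2=O)C(OCc2ccccc2)=C1OCc1ccccc1`: > 100000 nM (a limit of the assay)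

Every value recorded so far in this assay is a limit rather than a number: the limit of > 100000 nM in this assay, at which 3 of the 3 values shown sit. Going by the values given here, compound 2 therefore cannot be placed on a scale against the others; it sits at the same limit as compound 1 and compound 3, and no step between any two measured compounds can be computed, since none of them gives a number to compare.

Compound 4, `Nc1ccn(CCC2(N)OC(=O)C(OCc3ccccc3)=C2OCc2ccccc2)c(=O)n1`, has not yet been measured in this assay. It differs from compound 2 by a group of 8 heavy atoms (4 carbon, 3 nitrogen, 1 oxygen; one six-membered aromatic ring with 2 hetero atoms) in place of a group of 8 heavy atoms (4 carbon, 2 nitrogen, 2 oxygen; one six-membered aromatic ring with 2 hetero atoms), on a saturated chain carbon, two bonds along the chain from a saturated ring carbon. The shared core, with its two benzyloxy groups and the lactone, is kept unchanged.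

Among the compounds with values here, with no measured step to rest on, and with all three measured compounds at the limit, no step beyond the scatter is expected in this assay in either direction from this change. The estimate for compound 4 is 100000 nM, with a range from 30000 nM to 300000 nM, and the most likely outcome is that this assay again reports only a limit. The step is expected to be a number no higher from compound 2 to compound 4 (the limit leaves the size open), that is, nothing beyond the scatter.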

Compound 4, half-maximal inhibitory concentration: > 100000 nM
Compound 4 ended at the assay's limit; the forecaster's own chance of this, stated with the estimate: 75%; the middle value lies on the limit itself.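

In this assay no step can be read from compound 2 to compound 4, since both results are limits and not numbers: the limit of > 100000 nM in this assay, at which 4 of the 4 values shown sit.

The compounds shown leave open how far any of them lies past that limit, and whether any group on the shared core would give a measurable number in this assay.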